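The compounds below may be only part of what the source reports. "The series", "measured", "known", "first", "only" and "open" are said of these compounds alone.

Among the measured compounds shown here, in an ADME assay on Vero cells (Chlorocebus sabaeus) for cytotoxicity, read by resazurin assay, with a stated time of 72 h (on this read-out lower numbers stand for stronger inhibition and higher numbers for weaker inhibition), compound 1 `Cc1ccc(C(=O)CCN2CCN(c3ccc([N+](=O)[O-])cc3)CC2)cc1` gives 235000 nM, the higher of the two numbers so far, while compound 2 `O=C(CCN1CCN(c2ccc([N+](=O)[O-])cc2)CC1)c1ccc(F)c(Cl)c1` gives 116000 nM. Compound 3 `O=C(CCN1CCN(c2ccc([N+](=O)[O-])cc2)CC1)c1ccc(OC(F)(F)F)cc1` is not yet measured. It differs from compound 1 by trifluoromethoxy in place of methyl on an aromatic carbon, on an aromatic carbon, para to a large group. For the measured compounds named here, the one measured step bearing on this change, a 2.0-fold lower number from compound 1 to compound 2 (0.31 log units; beyond the scatter), is modest and also replaces the 4-methylphenyl. On that single step, a similarly modest move to a lower number is expected in this assay, estimated as a 1.9-fold lower number from compound 1 to compound 3 (0.27 log units; within the scatter). For compound 3 the expected value is 125000 nM, with an estimated range of 60000 nM to 240000 nM.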

Compound 3, half-maximal inhibitory concentration: 93200 nM
For compound 3 the middle estimate is 1.3-fold (0.13 log units) above the measured one, within the range that was stated.
By their numbers in this assay, from the lowest: compounds 3 and 2 (each within the scatter of the next); then compound 1.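

In this assay, trifluoromethoxy in place of methyl on this aromatic carbon, para to a large group, gives a 2.5-fold lower number from compound 1 to compound 3 (0.40 log units; beyond the scatter). Among the compounds shown here, this is the first change confined to that single substituent, so the position alone can move the number beyond the scatter, without the two-halogen pattern of compound 2. The step runs the same way as a 2.0-fold lower number from compound 1 to compound 2 (0.31 log units; beyond the scatter), and neither replacement of methyl goes against that direction. Nothing measured here explains the shift.

Still open, going by these compounds, is how an amine or a carboxylic acid on this aromatic carbon would read. On these data alone, a longer alkyl chain there is equally open.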